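The source may report more compounds than this note shows. Statements on the series, on what has been measured and on what is new or still open speak of the compounds shown alone.

Measured so far:
- compound 1 `CC(=O)Oc1ccc(/C=C/C(=O)OC2CCCCC2)cc1OC(C)=O`: 200 nM
- compound 2 `O=C(/C=C/c1ccc(O)c(O)c1)Nc1ccc(C(F)(F)F)cc1`: 1400 nM

In a functional assay on B16 cells (Mus musculus) for inhibition (a higher number here means a weaker inhibitor, a lower number a stronger inhibitor), compound 2 gives 1400 nM, the higher of the two numbers. It is therefore the weaker inhibitor of the pair, and its gap to compound 1 lies beyond the scatter.

Compound 3 `CC(C)c1ccc(NC(=O)/C=C/c2ccc(O)c(O)c2)cc1` has not yet been measured. It departs from compound 2 at one place: isopropyl in place of trifluoromethyl on an aromatic carbon, with isopropyl in place of trifluoromethyl on an aromatic carbon, para to a large group. For the measured compounds named here, no measured pair isolates this change, so the data give no direct guide to its effect. The expectation in this assay is therefore no shift beyond the scatter, with no firm direction. The expected step is a 1.2-fold lower number from compound 2 to compound 3 (0.07 log units; within the scatter). For compound 3 the estimated value is 1200 nM, with an expected range of 400 nM to 3600 nM.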

Compound 3, half-maximal inhibitory concentration: 3400 nM
The estimate for compound 3 lay 2.8-fold (0.45 log units) below the measured number; low and high end bracket the measured number.
By their numbers in this assay, from the lowest: compound 1; then compound 2; then compound 3.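

In this assay the aromatic carbon para to a large group responds to its substituent: isopropyl in place of trifluoromethyl gives a 2.4-fold higher number from compound 2 to compound 3 (0.39 log units; beyond the scatter) and so leaves the weaker inhibitor of this pair. The step is modest, yet it is beyond the scatter, and both groups count no hydrogen-bond donors, no hydrogen-bond acceptors and no net charge, so those counts do not separate them. No measurement shown here explains the difference between the two groups.

For the compounds shown here, with only two groups compared at this position, the trend cannot be told apart from a result particular to this pair, and a chlorine atom, a methoxy group, a nitrile or an amine there remains open. Compound 1 differs from compound 2 in more than one place, so compound 1 at 200 nM gives no reading on this position.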